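A few compounds are considered here, and "the series" means these few. Any claim that something is new, unique, unknown or untested is made for them only; others in the source may bear on it.

Measured in an ADME assay on HEK293 cells for displacement of a labelled ligand from 5-hydroxytryptamine receptor 7 (Homo sapiens), read by radioligand binding, with a stated time of 1 h; on this read-out higher numbers stand for weaker inhibition and lower numbers for stronger inhibition:
compound 1 `O=C1c2ccccc2S(=O)(=O)N1CCCCCCN1CCN(c2ccccc2Cl)CC1` — 120 nM
compound 2 `O=C1c2ccccc2S(=O)(=O)N1CCCCCCN1CCN(c2ccccc2C(F)(F)F)CC1` — 195 nM
compound 3 `O=C1c2ccccc2S(=O)(=O)N1CCCCCCN1CCN(c2cccc3ccccc23)CC1` — 20 nM

Compound 3 stands lowest of the three numbers; its steps from the other two, a 6.0-fold lower number from compound 1 to compound 3 (0.78 log units; beyond the scatter) and a 9.8-fold lower number from compound 2 to compound 3 (0.99 log units; beyond the scatter), are both beyond the scatter, whereas a 1.6-fold higher number from compound 1 to compound 2 (0.21 log units; within the scatter) is not. Compound 4 `O=C1c2ccccc2S(=O)(=O)N1CCCCCCN1CCN(c2ncccn2)CC1` carries pyrimidin-2-yl in place of naphthalen-1-yl on an amine nitrogen in a ring. Among the measured compounds shown here, the steps that bear on this change are the two arriving at compound 3, both modest and both showing a lower number once naphthalen-1-yl sits on that ring nitrogen in place of a substituted phenyl. For the measured compounds named here, removing naphthalen-1-yl is therefore expected to move the number up again, and with no measured analogue carrying pyrimidin-2-yl the expected step of a 15-fold higher number from compound 3 to compound 4 (1.18 log units; beyond the scatter) is taken as at least that large. Compound 4 is estimated at 300 nM, range 80 nM to 1200 nM.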

Compound 4, inhibition constant: 35 nM
For compound 4 the middle estimate is 8.6-fold (0.93 log units) above the measured one; the measured number lies below the stated range.
By their numbers in this assay, from the lowest: compounds 3 and 4 (each within the scatter of the next); then compounds 1 and 2 (each within the scatter of the next).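

In this assay, a single aromatic ring with 2 hetero atoms serves on this amine nitrogen as well as the 2 carbon-only aromatic rings of naphthalen-1-yl, with a 1.8-fold higher number from compound 3 to compound 4 (0.24 log units; within the scatter), so the larger group is not needed for a low number. Pyrimidin-2-yl also stands apart from both substituted phenyls, with a 5.6-fold lower number from compound 2 to compound 4 (0.75 log units; beyond the scatter) and a 3.4-fold lower number from compound 1 to compound 4 (0.54 log units; beyond the scatter). No measurement at hand accounts for these steps.

Going by these compounds, whether unsubstituted phenyl or pyridin-2-yl on this nitrogen would read with compound 3 and compound 4 remains open. So does the effect of a shorter chain.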